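Quinoxaline-diamine series: benzylamine substituent exchange on compound 2

The source may report more compounds than this note shows. Statements on the series, on what has been measured and on what is new or still open speak of the compounds shown alone.

Measured compounds:
- compound 2, `Nc1cc(N)c2nc(-c3ccccc3)c(NCc3ccc(Cl)c(Cl)c3)nc2c1`: 1950 nM
- compound 3, `CCOC(=O)[C@H](CCC(=O)O)NC(=O)c1ccc(Sc2nc3cc(N)cc(N)c3nc2-c2ccccc2)cc1`: 4790 nM
- compound 1, `CCOC(=O)[C@H](CCC(=O)O)NC(=O)c1ccc(CNc2nc3cc(N)cc(N)c3nc2-c2ccccc2)cc1`: < 100000 nM

All three were tested in a functional assay on IGROV-1 cells (Homo sapiens) for inhibition, read by sulforhodamine B assay, with a stated time of 48 h; on this read-out higher numbers stand for weaker inhibition of growth and lower numbers for stronger inhibition of growth. Compound 1 is reported only as a limit there, < 100000 nM (the limit of < 100000 nM in this assay, at which 1 of the 3 values shown sits). Among the two real numbers, compound 2 stands lowest in this assay, giving 1950 nM, while compound 3 gives 4790 nM, a gap that lies beyond the usual scatter.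

The next compound, compound 4, `COc1ccc(CNc2nc3cc(N)cc(N)c3nc2-c2ccccc2)cc1`, is not yet measured. It differs from compound 2 only in the benzylamine part: 4-methoxyphenyl in place of 3,4-dichlorophenyl on a saturated chain carbon bound to a nitrogen on an aromatic ring. For the measured compounds named here, no measured pair in the set shows the effect of this exchange, so the expectation rests on compound 2 alone. A modest weakening is expected rather than no change, with the estimated step being a 2.3-fold higher number from compound 2 to compound 4 (0.36 log units; beyond the scatter). Compound 4 is therefore expected to give 4500 nM in this assay, with a range from 1500 nM to 15000 nM.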

Compound 4, concentration for 50% growth inhibition: 12900 nM
For compound 4 the middle estimate is 2.9-fold (0.46 log units) below the measured one; the measured number falls inside the stated range.
By their numbers in this assay, from the lowest: compound 2; then compound 3; then compound 4.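

In this assay, for the compounds shown here, the group on the saturated chain carbon bound to a nitrogen on an aromatic ring proves sensitive to exchange, giving the first single-place step: a 6.6-fold higher number from compound 2 to compound 4 (0.82 log units; beyond the scatter). The change from 3,4-dichlorophenyl to 4-methoxyphenyl keeps 8 heavy atoms and one six-membered aromatic ring of carbon only, so this step arises without a change in either count, while the hydrogen-bond acceptors go from 0 to 1. Nothing given here accounts for the step.

Going by these compounds, the exchange removes both chlorines and adds the methoxy group in one move, so the share of each remains open. A plain phenyl, or a phenyl carrying a single chlorine or an amine, would be needed at this position to separate the two contributions.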